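The source may report more compounds than this note shows. Statements on the series, on what has been measured and on what is new or still open speak of the compounds shown alone.

Among the measured compounds shown here, compound 2 `Clc1ccc(-c2cn3ccnc3c(-c3ccc4ncn(C5CCCCC5)c4c3)n2)cc1` holds the highest of the two numbers so far in a functional assay on SW-620 cells (Homo sapiens) for inhibition, read by sulforhodamine B assay, with a stated time of 48 h, tested at 10 uM (a higher number here means more inhibition at the concentration tested (going by the name of the read-out), a lower number less inhibition), where compound 2 gives 14%. Its nearest neighbour, compound 1 `O=Cc1ccc(-c2cn3ccnc3c(-c3ccc4ncn(C5CCCCC5)c4c3)n2)cc1`, gives 4.21% in this assay, and the step of a number 9.8 percentage points higher from compound 1 to compound 2 (within the scatter) lies within the scatter, so the two cannot be set in order. Compound 3 `Brc1ccc(-c2cn3ccnc3c(-c3ccc4ncn(C5CCCCC5)c4c3)n2)cc1` differs from compound 2 by bromo in place of chloro on an aromatic carbon. For the measured compounds named here, no measured step exchanges one halogen for another; the one measured step, a number 9.8 percentage points higher from compound 1 to compound 2 (within the scatter), bears on it only loosely, being an exchange of a small group on the same aromatic carbon, and it stayed within the scatter. The step of a number 1 percentage points higher from compound 2 to compound 3 (within the scatter) is therefore expected to be small and within the scatter. In this assay compound 3 is estimated at 15%, with a range from 3% to 30%.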

Compound 3, a percentage reported as inhibition, at one concentration (the size of the read-out at that concentration, not a potency): 21.9%
Compound 3: middle estimate off by 6.9 percentage points, on the low side; the range from low to high includes it.
By their numbers in this assay, from the lowest: compounds 1, 2 and 3 (each within the scatter of the next, the first and the last beyond it).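

In this assay the exchange of one halogen for the other on this aromatic carbon, para to a large group, gives a number 7.9 percentage points higher from compound 2 to compound 3 (within the scatter), so chloro and bromo cannot be set in order here. Among the compounds shown here, the exchange of formyl for bromo at the same place, however, gives a number 17.7 percentage points higher from compound 1 to compound 3 (beyond the scatter), the first step to clear the scatter, which shows that the group on this carbon can change the read-out, if only modestly. No evidence at hand explains this difference.

The compounds shown leave open what fluoro or iodo would do at this place, and so whether the halogens follow any trend at all. They also leave open how an amine, a carboxylic acid or a methoxy group on this carbon would compare with bromo.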